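From methoxy to hydroxy on compound 2

This account rests on a few compounds, and the source may have more. Where it says the series, first, only, none or still open, it means among the compounds named here.

In a functional assay on MCF7 cells (Homo sapiens) for cytotoxicity, read by MTT assay, with a stated time of 72 h (on this read-out higher numbers stand for weaker inhibition and lower numbers for stronger inhibition), compound 2 (`COc1ccc(/C=C/C(=O)CC(C)=O)cc1`) gives 15800 nM, within the scatter of compound 1 (`COc1ccc(/C=C/C(=O)CC(C)=O)cc1OC`) at 10600 nM. Compound 3 (`Cc1cc(/C=C/c2ccc(O)c(O)c2)on1`) gives 6300 nM, a lower number than compound 2, beyond the scatter. Compound 4 (`CC(=O)CC(=O)/C=C/c1ccc(O)cc1`) has hydrogen in place of methyl on an oxygen on an aromatic ring. Among the compounds with values here, the only measured step is a 1.5-fold higher number from compound 1 to compound 2 (0.17 log units; within the scatter), from hydrogen in place of methoxy on an aromatic carbon. Within the data shown here, it bears only indirectly, as no measured step shows this exact change. Compound 3 differs from compound 2 in more than one place and gives no direct guide. A small move toward lower numbers in this assay, within the scatter, is expected: a 1.3-fold lower number from compound 2 to compound 4 (0.12 log units; within the scatter). For compound 4 the estimated value is 12000 nM, with an expected range of 6000 nM to 24000 nM.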

Compound 4, half-maximal inhibitory concentration: 19700 nM
For compound 4 the middle estimate is 1.6-fold (0.22 log units) below the measured one; the measured number falls inside the stated range.
By their numbers in this assay, from the lowest: compounds 3, 1, 2 and 4 (each within the scatter of the next, the first and the last beyond it).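

Methoxy to hydroxy is now a measured change on this aromatic ring: in this assay the number barely moves (a 1.2-fold higher number from compound 2 to compound 4 (0.10 log units; within the scatter)). Read with the earlier step (a 1.5-fold higher number from compound 1 to compound 2 (0.17 log units; within the scatter)), neither change among compounds 1, 2 and 4 goes beyond the scatter, so this series shows no measurable response to either edit. No available evidence bears on this result.

Going by these compounds, whether an ethyl group on this oxygen, or an amine in place of the hydroxy, would stay within the scatter remains open. On these data alone, compound 3 differs from these compounds in more than one place, so which feature separates it also remains open.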